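The compounds below may be only part of what the source reports. "The series", "measured", "known", "first", "only" and "open" are said of these compounds alone.

Compound 1 `CC1=CSC(O)(c2ccc(C)cc2)c2noc(=O)n21` gives > 100000 nM in a functional assay on A2780/DX3 cells (Homo sapiens) for antiproliferative activity, read by MTT assay, with a stated time of 3 days; on this read-out higher numbers stand for weaker inhibition and lower numbers for stronger inhibition.
Compound 2 `CC1=CSC(O)(c2cccc([N+](=O)[O-])c2)c2noc(=O)n21` gives 129000 nM in this assay.
Compound 3 `CCCCOC1(c2ccc(Br)cc2)SC=C(C)n2c1noc2=O` gives 78000 nM in this assay.

All three measured compounds share one core and weakly inhibit the growth of these cells, so the numbers are large throughout. For compound 1 the value is a limit of the assay and not a number (the limit of > 100000 nM in this assay, at which 1 of the 3 values shown sits). Among the two actual numbers, compound 2 stands highest; its nearest neighbour is compound 3, and the gap between them lies within the usual scatter, so the two cannot be placed in order.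

Compound 4 `CC1=CSC(O)(c2cccc(C(F)(F)F)c2)c2noc(=O)n21` has not yet been measured. It differs from compound 2 in a single place: trifluoromethyl in place of nitro on an aromatic carbon. Among the measured compounds shown here, no step between measured compounds matches this change, so any expectation must rest on compound 2 alone. The change is expected to shift the number little, if at all, no further than the scatter, with an estimated step of a 1.0-fold higher number from compound 2 to compound 4 (0.00 log units; within the scatter). Compound 4 is therefore expected to give about 130000 nM in this assay, most likely somewhere between 50000 nM and 320000 nM.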

Compound 4, half-maximal inhibitory concentration: 71000 nM
Compound 4: the middle estimate sits 1.8-fold (0.26 log units) above what was measured; the range from low to high includes it.
By their numbers in this assay, from the lowest: compounds 4, 3 and 2 (each within the scatter of the next).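

Setting trifluoromethyl in place of nitro on this aromatic carbon gives a 1.8-fold lower number from compound 2 to compound 4 (0.26 log units; within the scatter) in this assay. This is the only pair shown that differs in one place, so it gives the first direct reading of a change at this position. The hydrogen-bond acceptors counted for nitro are absent from trifluoromethyl, yet the numbers of compound 2 and compound 4 cannot be placed in order, and both remain large, so this single swap leaves inhibition of these cells weak.

On these data alone, whether an amine or a carboxylic acid at this same place would move the number beyond the scatter remains open. Compound 1 offers no further comparison, since its value is a limit and not a number: the limit of > 100000 nM in this assay, at which 1 of the 4 values shown sits.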